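Series notes: from compound 3 to compound 4

The compounds below may be only part of what the source reports. "The series", "measured", "known", "first", "only" and "open" are said of these compounds alone.

Three compounds of the series have numbers in a functional assay on Mahlavu cells (Homo sapiens) for antiproliferative activity, read by sulforhodamine B assay, with a stated time of 72 h; a higher number here means a weaker inhibitor, a lower number a stronger inhibitor. Compound 1 `FC(F)(F)c1ccc(CN2CCN(Cc3cc(-c4ccc(OCc5ccccc5Cl)cc4)on3)CC2)cc1` gives 3200 nM, compound 2 `N#Cc1cccc(COc2ccc(-c3cc(CN4CCN(Cc5ccc(C(F)(F)F)cc5)CC4)no3)cc2)c1` gives 10600 nM, and compound 3 `COc1cccc(COc2ccc(-c3cc(CN4CCN(Cc5ccc(C(F)(F)F)cc5)CC4)no3)cc2)c1` gives 1400 nM. Compound 3 thus stands lowest of the three: the step of a 2.3-fold lower number from compound 1 to compound 3 (0.36 log units; beyond the scatter) and the step of a 7.6-fold lower number from compound 2 to compound 3 (0.88 log units; beyond the scatter) both run toward it and both exceed the scatter, so it is the strongest inhibitor measured so far. Between the other two, a 3.3-fold higher number from compound 1 to compound 2 (0.52 log units; beyond the scatter).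

Compound 4 `COc1cc(COc2ccc(-c3cc(CN4CCN(Cc5ccc(C(F)(F)F)cc5)CC4)no3)cc2)cc(OC)c1OC` is not yet measured. It differs from compound 3 in one place: 3,4,5-trimethoxyphenyl in place of 3-methoxyphenyl on a saturated chain carbon bound to an oxygen on an aromatic ring. Going by the values given here, no measured step adds methoxy groups to a ring that already carries one; the steps at the same place exchange one whole ring for another, and a 2.3-fold lower number from compound 1 to compound 3 (0.36 log units; beyond the scatter) together with a 7.6-fold lower number from compound 2 to compound 3 (0.88 log units; beyond the scatter) shows that the identity of this ring shifts the number by modest amounts in either direction. Adding two further methoxy groups to the ring of compound 3 is untested here, so the direction remains open, and a step of modest size, if any, is expected, a 1.2-fold lower number from compound 3 to compound 4 (0.07 log units; within the scatter). In this assay compound 4 is expected to give about 1200 nM, within a range from 400 nM to 4000 nM.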

Compound 4, half-maximal inhibitory concentration: 5800 nM
Beside the measured number, compound 4's estimate is 4.8-fold (0.68 log units) below it; measured number above the stated range.
By their numbers in this assay, from the lowest: compound 3; then compounds 1, 4 and 2 (each within the scatter of the next, the first and the last beyond it).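

In this assay the position on a saturated chain carbon bound to an oxygen on an aromatic ring now shows a step that adds methoxy groups to a ring already carrying one rather than exchanging one ring for another, and a 4.1-fold higher number from compound 3 to compound 4 (0.62 log units; beyond the scatter) shows that, for this pair, the added groups cost activity beyond the scatter, so the low number of compound 3 does not carry over to the 3,4,5-trimethoxyphenyl ring. The other two steps, a 1.8-fold lower number from compound 2 to compound 4 (0.26 log units; within the scatter) and a 1.8-fold higher number from compound 1 to compound 4 (0.26 log units; within the scatter), both lie within the scatter, so compound 4 cannot be separated from either of the two rings it is compared with here, and compound 3 alone remains apart from the rest. Nothing at hand accounts for the step from the 3-methoxyphenyl ring to the 3,4,5-trimethoxyphenyl ring.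

The compounds shown leave open whether one added methoxy group, as in a dimethoxyphenyl ring, already carries part of this step or whether it takes both. Going by these compounds alone, they also leave open whether an ethoxy or a hydroxy group in place of the single methoxy group of compound 3 would hold a number near that of compound 3, 1400 nM.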